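This account rests on a few compounds, and the source may have more. Where it says the series, first, only, none or still open, it means among the compounds named here.

Among the measured compounds shown here, compound 1, `CN(C)C(=O)c1cc2cnc(Nc3ccc(NC(=O)C4(C(=O)Nc5ccc(Cl)c(C(F)(F)F)c5)CC4)cc3)nc2n1C1CCCC1`, is one of two compounds measured in a functional assay on NCI-H1299 cells (Homo sapiens) for inhibition, read by CCK-8 assay, with a stated time of 72 h, tested at 10 uM; on this read-out higher numbers stand for more inhibition of growth at the one concentration tested and lower numbers for less inhibition of growth. In this assay compound 1 gives 90.4%, the higher of the two numbers. The other measured compound, compound 2, `Nc1ccc(NC(=O)C2(C(=O)Nc3ccc(F)cc3)CC2)cc1F`, gives 59.2% in this assay, and that number lies beyond the usual scatter below compound 1. For the measured compounds named here, no pair of measured compounds differs in a single place, so no direct step is known.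

Compound 3, `CN(C)C(=O)c1cc2cnc(Nc3ccc(NC(=O)C4(C(=O)Nc5ccc(F)cc5)CC4)cc3)nc2n1C1CCCC1`, has not been measured. It differs from compound 1 in one place: 4-fluorophenyl in place of 4-chloro-3-(trifluoromethyl)phenyl on an amide-type nitrogen. A smaller group thus takes the place of a larger one on the same amide-type nitrogen.

For this change a downward step is expected, likely beyond the scatter, because compound 2, which also carries a 4-fluorophenyl group on an amide-type nitrogen, gives 59.2%. The step from compound 1 to compound 3 is estimated as a number 15.4 percentage points lower from compound 1 to compound 3 (beyond the scatter). Compound 3 is expected to give about 75% in this assay, within a range from 50% to 92%.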

Compound 3, percent growth inhibition at one concentration: 90.8%
Compound 3: middle estimate off by 15.8 percentage points, on the low side; low and high end bracket the measured number.
By their numbers in this assay, from the lowest: compound 2; then compounds 1 and 3 (each within the scatter of the next).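

In this assay, replacing 4-chloro-3-(trifluoromethyl)phenyl with 4-fluorophenyl on the amide-type nitrogen gives a number 0.4 percentage points higher from compound 1 to compound 3 (within the scatter). This position therefore accepts the smaller ring without a measurable change in this read-out, so neither the chlorine nor the trifluoromethyl group is needed to keep growth inhibition at this level at the one concentration tested. Nothing shown explains why the two groups read alike.

A single concentration cannot show whether the two compounds would separate at lower concentrations, since an equal percentage at one dose need not mean equal potency. On these data alone, it also remains open how far this position tolerates change, for example with an unsubstituted phenyl ring, a cyclohexyl ring or a pyridine ring on the same nitrogen.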